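Swapping a Chlorophenyl Ring for an Ethyl Ester

The compounds below may be only part of what the source reports. "The series", "measured", "known", "first", "only" and "open" are said of these compounds alone.

Compound 1, `CCCCCCCCc1ccc(OCC(=O)Cn2nnc(-c3ccc(C(=O)OC)cc3)n2)cc1`, gives 64% in an ADME assay on S9 fraction from liver (Rattus norvegicus) for metabolic stability, read by LC-MS, using NADPH, with a stated time of 30 min; a higher number here means that more of the compound is left, a lower number that less of the compound is left.
Compound 2, `CCCCCCCCc1ccc(OCC(=O)Cn2nnc(-c3cccc(C(=O)O)c3)n2)cc1`, gives < 5%, which is a limit of the assay rather than a number.
Compound 3, `CCCCCCCCc1ccc(OCC(=O)Cn2nnnc2-c2cccc(Cl)c2)cc1`, gives 41%.

Of the two numbers shown, compound 3 stands lowest; the nearest is compound 1, which sits higher by a margin beyond the scatter. Compound 4, `CCCCCCCCc1ccc(OCC(=O)Cn2nnnc2C(=O)OCC)cc1`, has not yet been measured. It differs from compound 3 in one place: ethoxycarbonyl in place of 3-chlorophenyl on an aromatic carbon.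

Only one measured step is shown, a number at least 59 percentage points lower from compound 1 to compound 2 (beyond the scatter), and it ends at the limit of < 5% in this assay, at which 1 of the 3 values shown sits. That step exchanges one aromatic group for another that carries an acid, so it does not speak directly to replacing an aromatic ring with an ester. What can be said is that compound 1 carries a methyl ester and still gives 64%, so a compound bearing an ester can still give a measurable number in this assay.

For the measured compounds named here, with no close precedent, no clear direction is expected, and any step is estimated to stay near the scatter: the expected step is a number 6 percentage points lower from compound 3 to compound 4 (within the scatter). Compound 4 is therefore estimated at 35%, within a range of 10% to 60%.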

Compound 4, percent of the compound remaining: 33%
The estimate for compound 4 lay 2 percentage points above the measured number, and the stated range covers the measured number.
By their numbers in this assay, from the lowest: compounds 4 and 3 (each within the scatter of the next); then compound 1. At a limit, below all of these: compound 2.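

In this assay, ethoxycarbonyl in place of 3-chlorophenyl gives a number 8 percentage points lower from compound 3 to compound 4 (within the scatter). At this position, then, a group with no ring can stand where a six-membered aromatic ring stood, and the two compounds cannot be told apart by this read-out. No measurement shown gives a reason for this result.

Open, from the compounds shown here alone, is how a carboxylic acid, an amide or a simple methyl ester would read in this assay on this same aromatic carbon, with the rest of compound 4 unchanged. Also open, going by these compounds, is whether a longer alkyl ester or a small amine would stay within the scatter of compound 4, or move clearly away from it.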